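The source may hold more compounds than are shown below. What is called first, only, known or untested is meant among the compounds shown, and "the series" means these compounds.

In a functional assay on Huh-7 cells (Homo sapiens) for inhibition, read by MTT assay, with a stated time of 48 h (a higher number here means a weaker inhibitor, a lower number a stronger inhibitor), compound 1 `COc1ccc2c(=O)c(/C=C/C(=O)Nc3ccccc3Cl)coc2c1` gives 58400 nM, compound 2 `COc1cccc(NC(=O)/C=C/c2coc3cc(OC)ccc3c2=O)c1` gives 11100 nM and compound 3 `COc1ccc2c(=O)c(/C=C/C(=O)NCc3ccc(F)cc3)coc2c1` gives 21000 nM. All three share one core and differ only in the group on the amide-type nitrogen. The number for compound 3 cannot be told apart from that of compound 2, and it lies clearly under that of compound 1. The next compound is compound 4 `COc1ccc2c(=O)c(/C=C/C(=O)NCc3ccccc3F)coc2c1`, and its change is small: 2-fluorophenyl in place of 4-fluorophenyl on a saturated chain carbon bound to an amide-type nitrogen. Put simply, 2-fluorophenyl stands in place of 4-fluorophenyl on a saturated chain carbon bound to an amide-type nitrogen. For the measured compounds named here, no measured pair shows a change of this kind, so the evidence is indirect. Swapping the whole group gave only modest changes, with a 5.3-fold lower number from compound 1 to compound 2 (0.72 log units; beyond the scatter) and a 2.8-fold lower number from compound 1 to compound 3 (0.44 log units; beyond the scatter), while the remaining pair shows a 1.9-fold higher number from compound 2 to compound 3 (0.28 log units; within the scatter). A smaller edit should hardly move the number in this assay. The expected result is a 1.2-fold higher number from compound 3 to compound 4 (0.08 log units; within the scatter), which means no clear shift in either direction. For compound 4 the estimated value is 25000 nM, with an expected range of 10000 nM to 60000 nM.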

Compound 4, half-maximal inhibitory concentration: 8450 nM
For compound 4 the middle estimate is 3.0-fold (0.47 log units) above the measured one, and the stated range ends above it.
By their numbers in this assay, from the lowest: compounds 4, 2 and 3 (each within the scatter of the next, the first and the last beyond it); then compound 1.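

Moving the single fluorine matters in this assay: the atoms stay the same, yet going from 4-fluorobenzyl to 2-fluorobenzyl gives a step beyond the scatter (a 2.5-fold lower number from compound 3 to compound 4 (0.40 log units; beyond the scatter)), so the number here depends on where the fluorine sits, not only on which kind of group is present. With 2-fluorobenzyl on the amide-type nitrogen, the result cannot be told apart from that of the 3-methoxyphenyl group (a 1.3-fold lower number from compound 2 to compound 4 (0.12 log units; within the scatter)), while it remains clearly apart from that of the 2-chlorophenyl group (a 6.9-fold lower number from compound 1 to compound 4 (0.84 log units; beyond the scatter)). No measurement available here explains why the place of the fluorine changes the number. Still open, going by these compounds, is what a plain benzyl group with no fluorine would give. Also open, on these data alone, is whether a longer chain carrying 2-fluorophenyl would give a number close to that of compound 4.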